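Expected Growth Inhibition After Swapping the Aryl Group

This account rests on a few compounds, and the source may have more. Where it says the series, first, only, none or still open, it means among the compounds named here.

Compound 1 `Cc1cc(=O)c2c(O)c(CN(C(C)C)C(C)C)c(O)c([C@H]3CCN(C)C[C@H]3O)c2o1` gives 11% in a functional assay on MIA PaCa-2 cells (Homo sapiens) for inhibition, read by MTT assay, with a stated time of 48 h, tested at 10 uM; a lower number here means less inhibition of growth, a higher number more inhibition of growth at the concentration tested.
Compound 2 `Cc1oc2c([C@H]3CCN(C)C[C@H]3O)c(O)cc(O)c2c(=O)c1C(O)c1ccc([N+](=O)[O-])cc1` gives 2% in this assay.

Both measured compounds show only weak inhibition of growth. Compound 2 has the lower of the two numbers, but its gap to compound 1 lies within the usual scatter of such measurements, so the two cannot be told apart on these data. No comparison between two measured compounds that differ in a single place is available here, so nothing is yet known about how any one structural change shifts the read-out.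

Compound 3 `Cc1oc2c([C@H]3CCN(C)C[C@H]3O)c(O)cc(O)c2c(=O)c1C(O)c1cc(F)cc(F)c1` is the untested compound. It differs from compound 2 in one place: 3,5-difluorophenyl in place of 4-nitrophenyl on a saturated chain carbon bound to an aromatic carbon and an oxygen on a saturated carbon. Since both measured compounds sit near the bottom of the scale and no shift from a single change has been seen, the step is expected to stay within the scatter, with no clear direction. The estimated step is a number 3 percentage points higher from compound 2 to compound 3 (within the scatter). Compound 3 is thus expected to give 5%, in the range -10% to 20%.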

Compound 3, percent growth inhibition at one concentration: 6%
Compound 3: middle estimate off by 1 percentage points, on the low side; measured number inside the range.
By their numbers in this assay, from the lowest: compounds 2, 3 and 1 (each within the scatter of the next).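

Going by these compounds alone, this is the first comparison between two compounds that differ in one place: on a saturated chain carbon bound to an aromatic carbon and an oxygen on a saturated carbon, 3,5-difluorophenyl in place of 4-nitrophenyl gives a number 4 percentage points higher from compound 2 to compound 3 (within the scatter) in this assay. The entering group has fluorine atoms and 0 hydrogen-bond acceptors, while the leaving group has nitrogen and oxygen atoms and 2 hydrogen-bond acceptors, yet this read-out does not tell the two compounds apart. No measurement is available that could explain this result.

From the compounds shown here alone, what stays open is whether a very different group at this place, such as a carboxylic acid, an amine or a longer alkyl chain in place of the aromatic ring, would move the number beyond the scatter. Compound 1 differs from compound 2 and compound 3 in more than one place, so it cannot help answer that question.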